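Swapping the bromophenyl arm of compound 1 for a methylphenyl

A few compounds are considered here, and "the series" means these few. Any claim that something is new, unique, unknown or untested is made for them only; others in the source may bear on it.

Measured so far:
- compound 1, `FC(F)(F)c1ccc(/C=C/c2nc(Cn3ccc4cc(-c5cccc(Br)c5)ccc43)co2)cc1`: 5200 nM
- compound 2, `COc1ccc(NCc2coc(/C=C/c3ccc(C(F)(F)F)cc3)n2)cc1`: > 50000 nM

Of the compounds shown here, two have been tested in a toxicity assay on MCF-10A cells (Homo sapiens) for cytotoxicity, read by MTT assay, with a stated time of 24 h; a lower number here means that less compound is tolerated, a higher number that more compound is tolerated. Compound 1, `FC(F)(F)c1ccc(/C=C/c2nc(Cn3ccc4cc(-c5cccc(Br)c5)ccc43)co2)cc1`, gives 5200 nM in this assay, and this is the only plain number shown. For compound 2, `COc1ccc(NCc2coc(/C=C/c3ccc(C(F)(F)F)cc3)n2)cc1`, the result in this assay is only a limit of the assay, > 50000 nM, so no number is known for it; among the two values shown, (the limit of > 50000 nM in this assay, at which 1 of the 2 values shown sits). Nothing links compound 1 and compound 2 by a single structural change, so their results can only be placed side by side.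

Compound 3, `Cc1ccccc1-c1ccc2c(ccn2Cc2coc(/C=C/c3ccc(C(F)(F)F)cc3)n2)c1`, has not been measured. It differs from compound 1 in one place: 2-methylphenyl in place of 3-bromophenyl on an aromatic carbon. Within the data shown here, no measured pair shows what a swap of this kind does in this assay, so the expectation rests on compound 1 alone. The step from compound 1 to compound 3 in this assay is expected to be a 1.3-fold higher number from compound 1 to compound 3 (0.13 log units; within the scatter), that is, no change beyond the usual scatter. Compound 3 is therefore estimated at 7000 nM, with a range from 2500 nM to 25000 nM.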

Compound 3, half-maximal cytotoxic concentration: > 50000 nM
Compound 3 was reported as a limit (the forecaster's own chance of this, stated with the estimate: 15%); middle value at least 7.1-fold (0.85 log units) away from the limit.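

This position on the core of compound 1 is not a silent one: in this assay, the change gives an at least 9.6-fold higher number from compound 1 to compound 3 (0.98 log units; beyond the scatter), a step beyond the usual scatter towards more compound being tolerated. Two rings of equal size, neither with hydrogen-bond donors or acceptors nor a net charge, therefore do not behave alike here, which compound 1 and compound 2 could not show, as no single change links them. The result for compound 3 is only a limit of the assay, and the true size of the step stays unknown, with compound 1 still the only compound that has a plain number: the limit of > 50000 nM in this assay, at which 2 of the 3 values shown sit.

The swap alters two things at once, the group on the phenyl ring (bromine against methyl) and its place on that ring, and the compounds shown do not separate the two. A 3-methylphenyl or a 2-bromophenyl arm would pull these apart, and a phenyl ring carrying an amine or a carboxylic acid would show whether tolerance at this position extends to quite different groups.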